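Adding a Second Chloro to Compound 2

The compounds below may be only part of what the source reports. "The series", "measured", "known", "first", "only" and "open" are said of these compounds alone.

Compound 1 `Nc1cccc(F)c1C(=O)NNc1cccc(Cl)c1` gives > 1800000 nM as a limit
Compound 2 `Nc1cccc(F)c1C(=O)NNc1ccc(Cl)cc1` gives 373000 nM as a number

Going by the values given here, in a toxicity assay on Vero cells (Chlorocebus sabaeus) for cytotoxicity, read by colorimetric assay and MTT assay, with a stated time of 72 h (on this read-out higher numbers stand for lower toxicity in this test and lower numbers for higher toxicity in this test), compound 2 gives 373000 nM as the only actual number so far. Compound 1 stands at a limit of the assay (> 1800000 nM) and not at a number. The two readings leave compound 2 on the side of higher toxicity in this test.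

Compound 3 `Nc1cccc(F)c1C(=O)NNc1ccc(Cl)c(Cl)c1` follows from compound 2 by a single change chloro in place of hydrogen on an aromatic carbon with chloro in place of hydrogen on an aromatic carbon, ortho to a chloro group and meta to a large group. Among the compounds with values here, no measured pair shows such a change, so the expectation here is a matter of judgement. Starting from compound 2 at 373000 nM in this assay a moderate move toward lower numbers is expected, somewhat beyond the usual scatter. The expected size is a 2.5-fold lower number from compound 2 to compound 3 (0.40 log units; beyond the scatter) in that direction. Compound 3 is estimated at 150000 nM (expected range 50000 nM to 400000 nM).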

Compound 3, half-maximal cytotoxic concentration: > 1800000 nM
Compound 3 gave a limit, no number (the forecaster's own chance of this, stated with the estimate: 10%); middle value at least 12-fold (1.07 log units) from the limit.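

In this assay, chloro in place of hydrogen on an aromatic carbon, ortho to a chloro group and meta to a large group, gives an at least 4.8-fold higher number from compound 2 to compound 3 (0.68 log units; beyond the scatter). Going by these compounds alone, this is the first sign at this position that the change moves the reading toward lower toxicity in this test and not toward higher toxicity, something the earlier compounds could not show, since each of them carries a single chloro. Compound 3 gives > 1800000 nM, which is a limit of the assay and not a number, so the full size of the step stays unknown because the reading stops there: the limit of > 1800000 nM in this assay, at which 2 of the 3 values shown sit.

The step from compound 1 to compound 3 cannot be read, which leaves open whether the added chloro changes anything on that side, as both readings are limits. The compounds shown also leave open whether a methoxy group, an amine or a carboxylic acid in place of the new chloro would give the same shift as chloro does, or whether this shift belongs to chloro alone.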